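This account rests on a few compounds, and the source may have more. Where it says the series, first, only, none or still open, it means among the compounds named here.

Measured set, in a functional assay on HCT-116 cells (Homo sapiens) for antiproliferative activity, read by MTT assay, with a stated time of 72 h; on this read-out higher numbers stand for weaker inhibition and lower numbers for stronger inhibition:
compound 1 `COc1ncc(-c2ccc3nc(NC(=O)NCCN4CCCC4)sc3c2)cc1NS(=O)(=O)c1ccc(F)cc1` gives 310 nM
compound 2 `CCN(CC)CCNC(=O)Nc1nc2ccc(-c3cnc(OC)c(NS(=O)(=O)c4ccc(F)cc4)c3)cc2s1` gives 300 nM
compound 3 `CNC(=O)Nc1nc2ccc(-c3cnc(OC)c(NS(=O)(=O)c4ccc(F)cc4)c3)cc2s1` gives 870 nM

Compound 3 carries the highest number of the three. The steps of a 2.8-fold higher number from compound 1 to compound 3 (0.45 log units; beyond the scatter) and a 2.9-fold higher number from compound 2 to compound 3 (0.46 log units; beyond the scatter) run the same way and are of like size, while a 1.0-fold lower number from compound 1 to compound 2 (0.01 log units; within the scatter). Compound 4 `COc1ncc(-c2ccc3nc(NC(=O)NCCN4CCCCC4)sc3c2)cc1NS(=O)(=O)c1ccc(F)cc1` differs from compound 3 by (piperidin-1-yl)methyl in place of hydrogen on a saturated chain carbon bound to an amide-type nitrogen. This is the reverse of those two steps, with piperidin-1-yl in place of pyrrolidin-1-yl or diethylamino on the chain. The step in this assay is therefore expected to be a 2.8-fold lower number from compound 3 to compound 4 (0.45 log units; beyond the scatter), a modest lowering beyond the scatter, because compound 1 reaches 310 nM and compound 2 reaches 300 nM with comparable chains. Compound 4 is estimated at 310 nM, within 180 nM to 550 nM.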

Compound 4, half-maximal inhibitory concentration: 610 nM
The estimate for compound 4 lay 2.0-fold (0.29 log units) below the measured number; the measured number lies above the stated range.
By their numbers in this assay, from the lowest: compounds 2, 1, 4 and 3 (each within the scatter of the next, the first and the last beyond it).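

In this assay the 2-(piperidin-1-yl)ethyl chain does not clearly separate from methyl on the urea nitrogen, as a 1.4-fold lower number from compound 3 to compound 4 (0.15 log units; within the scatter) stays within the scatter, so the lowering seen with the pyrrolidin-1-yl and diethylamino chains does not extend to this chain. Among the chain ends, a 2.0-fold higher number from compound 2 to compound 4 (0.31 log units; beyond the scatter) lies beyond the scatter, whereas a 2.0-fold higher number from compound 1 to compound 4 (0.29 log units; within the scatter) lies within it. Nothing available explains the result for the piperidin-1-yl group. Still open, on these data alone, is whether a morpholin-4-yl end group or a longer propyl link would follow compound 1 or compound 4.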